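Cytotoxicity Limits and a Formylamino Replacement

The source may hold more compounds than are shown below. What is called first, only, known or untested is meant among the compounds shown, and "the series" means these compounds.

Measured compounds:
Compound 1, `O=C1O[C@@H](CN2CCCCC2)CN1c1ccc(-n2cc(-c3ccccn3)cn2)c(F)c1`: in an ADME assay on HEK293-A cells (Homo sapiens) for cytotoxicity, read by MTT assay, with a stated time of 48 h (on this read-out lower numbers stand for stronger inhibition and higher numbers for weaker inhibition), compound 1 gives > 400 ug/mL, which is a limit of the assay and not a number.
Compound 2, `O=C1O[C@@H](Cn2ccnc2)CN1c1ccc(-n2cc(-c3ccccn3)cn2)c(F)c1`: in this assay compound 2 gives > 400 ug/mL, again a limit of the assay.

For the measured compounds named here, compound 2 thus stands only at a limit in this assay, and the one further value shown, that of compound 1, is a limit as well, so both sit at the limit of > 400 ug/mL in this assay, at which 2 of the 2 values shown sit. Going by the values given here, the single measured step, a step that the two limits leave unreadable from compound 1 to compound 2, therefore has no readable size. Compound 3, `O=CNC[C@H]1CN(c2ccc(-n3cc(-c4ccccn4)cn3)c(F)c2)C(=O)O1`, differs from compound 2 by formylamino in place of 1H-imidazol-1-yl on a saturated chain carbon bound to a saturated ring carbon. Among the compounds with values here, the only measured step touches the same saturated chain carbon and yields no size, so nothing among the measured compounds points to a step in this assay beyond the scatter in either direction. Compound 3 is therefore expected to show a number no higher from compound 2 to compound 3 (the limit leaves the size open), that is, no change beyond the scatter. The estimate for compound 3 in this assay is 400 ug/mL, within 200 ug/mL to 800 ug/mL, with a limit rather than a number the likeliest outcome.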

Compound 3, half-maximal inhibitory concentration: > 400 ug/mL
Compound 3 was reported as a limit (the forecaster's own chance of this, stated with the estimate: 80%); the middle value lies on the limit itself.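

In this assay compound 3 gives > 400 ug/mL, again a limit of the assay and not a number. No new step can be read among compound 1, compound 2 and compound 3, because all three stand at the same limit: the limit of > 400 ug/mL in this assay, at which 3 of the 3 values shown sit. The compounds shown leave open how far their true values lie from one another.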